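This account rests on a few compounds, and the source may have more. Where it says the series, first, only, none or still open, it means among the compounds named here.

In a functional assay on B16-F0 cells (Mus musculus) for inhibition, read by CCK-8 assay, with a stated time of 48 h (a higher number here means a weaker inhibitor, a lower number a stronger inhibitor), compound 2 (`COc1cc(-c2ccnc3cc(-c4ccc(Cl)cc4)nn23)cc(OC)c1OC`) gives 4090 nM. Compound 3 (`Cn1ccc2cc(-c3cc4nccc(-c5ccc(F)cc5)n4n3)ccc21`) gives 4780 nM, and these two values lie within the scatter of each other. Compound 1 (`COc1cc(-c2ccnc3cc(-c4cn(CO)c5ccccc45)nn23)cc(OC)c1OC`) stands well apart at 93 nM, a clearly stronger result than that of compound 2, and the gap lies far beyond the scatter. Compound 2 therefore sits at the weak end of this small set, level with compound 3.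

Compound 4 (`COc1cc(-c2ccnc3cc(-c4cccc(C#N)c4)nn23)cc(OC)c1OC`) has not yet been measured. It keeps the core of compound 2 and carries 3-cyanophenyl in place of 4-chlorophenyl on an aromatic carbon of a five-membered aromatic ring with 2 nitrogen: 3-cyanophenyl in place of 4-chlorophenyl on an aromatic carbon. The entering group is again one six-membered aromatic ring of carbon only, but it brings a hydrogen-bond acceptor that the leaving group lacks. Going by the values given here, no measured pair isolates an exchange of this kind, so the data offer no direct guide to its size. The expected result in this assay is therefore no step beyond the scatter, and the estimated change is a 1.4-fold lower number from compound 2 to compound 4 (0.13 log units; within the scatter). For compound 4 the expected value is 3000 nM, with an estimated range from 1000 nM to 9000 nM.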

Compound 4, half-maximal inhibitory concentration: > 10000 nM
Compound 4: a limit, no number; the forecaster's own chance of this, stated with the estimate: 10%; at least 3.3-fold (0.52 log units) between middle value and limit.
By their numbers in this assay, from the lowest: compound 1; then compounds 2 and 3 (each within the scatter of the next). At a limit, above all of these: compound 4.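

Replacing 4-chlorophenyl with 3-cyanophenyl on this aromatic carbon gives an at least 2.4-fold higher number from compound 2 to compound 4 (0.38 log units; beyond the scatter), so this position does respond to a change of substituent, even though the leaving and entering groups each hold one six-membered aromatic ring of carbon only. Going by these compounds alone, this is the first step in the set that isolates a change at one place, and it runs towards a weaker result in this assay. For compound 4 the reading is a limit of the assay and not a number, so the step gives only the smallest size the change can have: the limit of > 10000 nM in this assay, at which 1 of the 4 values shown sits.

The exchange removes the chlorine, adds the nitrile and moves the substituent on the phenyl ring all at once, so the compounds shown do not tell which of these matters, or whether any one alone would be enough. As far as these compounds go, it also remains open how this position would respond to a phenyl ring carrying an amine or a carboxylic acid, and whether either would give a reading that is a number rather than a limit.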